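This account rests on a few compounds, and the source may have more. Where it says the series, first, only, none or still open, it means among the compounds named here.

Compound 1 `C=C1[C@@H](OC(C)=O)C[C@@H]2[C@](C)(CO[Si](C)(C)C(C)(C)C)[C@H](OC(C)=O)CC[C@@]2(C)[C@@H]1C[C@@H](Nc1ccccc1)C1=CCOC1=O` gives 5710 nM in a functional assay on KB cells (Homo sapiens) for cytotoxicity, read by sulforhodamine B assay; a lower number here means a stronger inhibitor, a higher number a weaker inhibitor. For the measured compounds named here, compound 2 `C=C1[C@@H](OC(C)=O)C[C@@H]2[C@](C)(CO[Si](C)(C)C(C)(C)C)[C@H](OC(C)=O)CC[C@@]2(C)[C@@H]1C[C@@H](Nc1ccccc1F)C1=CCOC1=O` gives 4740 nM in this assay; the only measured step, a 1.2-fold lower number from compound 1 to compound 2 (0.08 log units; within the scatter), stays within the scatter, so the two compounds are read as equal on this number. Compound 3 `C=C1[C@@H](OC(C)=O)C[C@@H]2[C@](C)(COC=O)[C@H](OC(C)=O)CC[C@@]2(C)[C@@H]1C[C@@H](Nc1ccc(O)cc1)C1=CCOC1=O`, which carries a formate in place of the silyl ether and an added hydroxy group, gives 28900 nM in this assay. That is the highest of the three numbers; its gap to compound 1 and its gap to compound 2 both lie beyond the scatter.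

Compound 4 `C=C1[C@@H](OC(C)=O)C[C@@H]2[C@](C)(COC=O)[C@H](OC(C)=O)CC[C@@]2(C)[C@@H]1C[C@@H](Nc1ccccc1)C1=CCOC1=O` is not yet measured. It differs from compound 3 in one place: hydrogen in place of hydroxy on an aromatic carbon. Going by the values given here, no measured step isolates this change; the step of a 1.2-fold lower number from compound 1 to compound 2 (0.08 log units; within the scatter) concerns a different substitution on the same ring and lies within the scatter. Among the compounds with values here, compound 4 also differs from compound 1 only by the formate versus the silyl ether, and that pair has no measured step either. Within the data shown here, the only guide is that compound 3 sits well above compounds 1 and 2 while carrying both changes. The number for compound 4 is therefore expected between them, with a step of a 2.4-fold lower number from compound 3 to compound 4 (0.38 log units; beyond the scatter) toward a lower number. Compound 4 is estimated at 12000 nM, in the range 5000 nM to 30000 nM.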

Compound 4, half-maximal inhibitory concentration: 32100 nM
Compound 4: the middle estimate sits 2.7-fold (0.43 log units) below what was measured; measured number above the stated range.
By their numbers in this assay, from the lowest: compounds 2 and 1 (each within the scatter of the next); then compounds 3 and 4 (each within the scatter of the next).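

In this assay, going from 4-hydroxyphenyl to phenyl gives a 1.1-fold higher number from compound 3 to compound 4 (0.05 log units; within the scatter), so with the formate in place, the hydroxy group on the aromatic carbon makes no readable difference on this number. For the compounds shown here, with the anilino group held constant, the formate in place of the silyl ether gives a 5.6-fold higher number from compound 1 to compound 4 (0.75 log units; beyond the scatter), so this change on the oxygen on a saturated carbon, rather than the change on the aromatic ring, is the one that moves the number beyond the scatter. No measurement at hand gives a reason for either step.

The silyl ether and the formate are the only groups shown on that oxygen, so it remains open how a free alcohol, a methyl ether or a benzoate would read there. Hydroxy on the ring is seen only with the formate and fluoro only with the silyl ether, which leaves open whether either result carries over to the other background and how an amine or a carboxylic acid on the same ring would read.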